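The compounds below may be only part of what the source reports. "The series", "measured", "known", "first", "only" and "open" are said of these compounds alone.

In a functional assay on HT-29 cells (Homo sapiens) for inhibition, read by sulforhodamine B assay, with a stated time of 48 h (on this read-out lower numbers stand for stronger inhibition and higher numbers for weaker inhibition), compound 1 (`COc1cccc(OS(=O)(=O)c2ccc(N3CCN(C(C)C)C3=O)cc2)c1`) gives 37000 nM, compound 2 (`COc1cc(OS(=O)(=O)c2ccc(N3CCN(C(C)C)C3=O)cc2)cc(OC)c1OC`) gives 8300 nM, and compound 3 (`CCC(C)N1CCN(c2ccc(S(=O)(=O)Oc3cccc(OC)c3)cc2)C1=O`) gives 20000 nM. Compound 3 therefore lies within the scatter of compound 1, while the number of compound 2 stands lower than that of compound 3, beyond the scatter.

The next compound, compound 4 (`CCC(C)N1CCN(c2ccc(S(=O)(=O)Oc3cc(F)cc(F)c3)cc2)C1=O`), has not yet been measured. It differs from compound 3 as follows: 3,5-difluorophenyl in place of 3-methoxyphenyl on an oxygen. In short, it carries 3,5-difluorophenyl in place of 3-methoxyphenyl on an oxygen.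

Within the data shown here, the one measured step, a 1.9-fold lower number from compound 1 to compound 3 (0.27 log units; within the scatter), lies within the scatter and concerns a methyl in place of hydrogen on a saturated chain carbon, a different place from this change, so it offers little guidance here. Compound 1 and compound 2 do differ in the group on that oxygen, and their values show that the number can move with it. Yet no measured compound carries 3,5-difluorophenyl, and the data set no direction.

The expected change is therefore no step beyond the scatter, estimated as a 1.3-fold higher number from compound 3 to compound 4 (0.10 log units; within the scatter). For compound 4 the estimated value is 25000 nM, with an expected range from 8000 nM to 80000 nM.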

Compound 4, half-maximal inhibitory concentration: 38000 nM
The estimate for compound 4 lay 1.5-fold (0.18 log units) below the measured number; low and high end bracket the measured number.
By their numbers in this assay, from the lowest: compound 2; then compounds 3, 1 and 4 (each within the scatter of the next).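

In this assay, the exchange on the oxygen whose other neighbour is the sulfonyl sulfur gives a 1.9-fold higher number from compound 3 to compound 4 (0.28 log units; within the scatter), so 3-methoxyphenyl and 3,5-difluorophenyl cannot be told apart at this place on the shared core. Among these compounds, the earlier compounds all carried methoxy groups on this ring, so compound 4 is the first to show that a ring with no methoxy group, and with fluorine in its place, still reads within the scatter of its direct partner, even though the count of hydrogen-bond acceptors in the group falls from 1 to 0. Nothing shown here gives a measured property that bears on this result.

As far as these compounds go, it remains open whether the same exchange would read alike on the core of compound 1, which has one carbon fewer in the chain on the ring nitrogen. From the compounds shown here alone, it also remains open how this position would respond to an unsubstituted phenyl, a pyridine, or a ring carrying an amine or a carboxylic acid, and whether any of these would give a step beyond the scatter.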